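This account rests on a few compounds, and the source may have more. Where it says the series, first, only, none or still open, it means among the compounds named here.

Measured compounds:
compound 1 `O=C1c2c[n+]([O-])c3ccccc3c2C(=O)c2c1c1ccccc1n2Cc1cn([C@H]2O[C@H](CO)[C@@H](O)[C@H]2O)nn1` — 1490 nM
compound 2 `O=C1c2c[n+]([O-])c3ccccc3c2C(=O)c2c1c1ccccc1n2CCCCN1CCCCC1` — 150 nM
compound 3 `CC1(C)OC[C@H](Cn2cc(Cn3c4c(c5ccccc53)C(=O)c3c[n+]([O-])c5ccccc5c3C4=O)nn2)O1` — 530 nM

These three share one core and differ only in the group on the aromatic nitrogen. In a functional assay on MCF7 cells (Homo sapiens) for cytotoxicity, read by MTT assay, with a stated time of 72 h (on this read-out higher numbers stand for weaker inhibition and lower numbers for stronger inhibition), compound 2 gives the lowest number, and its gaps to compound 3 and to compound 1 both lie beyond the usual scatter, so compound 2 is the most potent of the three. For the measured compounds named here, the one step measured between single-point neighbours, a 2.8-fold lower number from compound 1 to compound 3 (0.45 log units; beyond the scatter), concerns a different kind of change and says little about chain length.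

Compound 4 `O=C1c2c[n+]([O-])c3ccccc3c2C(=O)c2c1c1ccccc1n2CCN1CCCCC1` shortens the chain of compound 2: piperidin-1-yl in place of 2-(piperidin-1-yl)ethyl on a saturated chain carbon, two bonds along the chain from an aromatic nitrogen. Going by the values given here, no measured step tells how this chain length matters, so only a small step is expected, a 1.7-fold higher number from compound 2 to compound 4 (0.22 log units; within the scatter). Compound 4 is therefore expected to give about 250 nM in this assay, between 80 nM and 800 nM.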

Compound 4, half-maximal inhibitory concentration: 620 nM
Compound 4: middle estimate off by 2.5-fold (0.39 log units), on the low side, and the stated range covers the measured number.
By their numbers in this assay, from the lowest: compound 2; then compounds 3 and 4 (each within the scatter of the next); then compound 1.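

In this assay, shortening 4-(piperidin-1-yl)butyl to 2-(piperidin-1-yl)ethyl on the aromatic nitrogen gives a 4.1-fold higher number from compound 2 to compound 4 (0.62 log units; beyond the scatter) and lies beyond the scatter. The piperidine ring stays the same, so this position responds to chain length alone, and the longer chain gives the lower number. Nothing measured here explains this difference.

The intermediate 3-(piperidin-1-yl)propyl chain, or any chain longer than the butyl one, could show whether the numbers follow a steady trend. On these data alone, whether morpholine at the chain end would serve like piperidine also remains open.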